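Removing the Bromine from a Cytotoxic Lactone

The source may report more compounds than this note shows. Statements on the series, on what has been measured and on what is new or still open speak of the compounds shown alone.

Measured compounds in a functional assay on MCF7 cells (Homo sapiens) for cytotoxicity, read by sulforhodamine B assay; a higher number here means a weaker inhibitor, a lower number a stronger inhibitor:
Compound 1, `C=C1[C@@H](OC(C)=O)C[C@@H]2[C@](C)(COC=O)[C@H](OC(C)=O)CC[C@@]2(C)[C@@H]1C[C@@H](Nc1ccc(Br)cc1)C1=CCOC1=O`, gives 11400 nM.
Compound 2, `C=C1[C@@H](OC(C)=O)C[C@@H]2[C@](C)(CO[Si](C)(C)C(C)(C)C)[C@H](OC(C)=O)CC[C@@]2(C)[C@@H]1C[C@@H](Nc1ccc(C(=O)O)cc1)C1=CCOC1=O`, gives 3990 nM.

Compound 1 has the higher of the two numbers and is thus the weaker inhibitor; compound 2 sits at a lower number, and the gap between them lies beyond the usual scatter. The two compounds differ in more than one place, and the gap cannot be tied to any single change. Compound 3, `C=C1[C@@H](OC(C)=O)C[C@@H]2[C@](C)(COC=O)[C@H](OC(C)=O)CC[C@@]2(C)[C@@H]1C[C@@H](Nc1ccccc1)C1=CCOC1=O`, keeps the core of compound 1 and differs from it in one spot only: hydrogen in place of bromo on an aromatic carbon. The (4-bromophenyl)amino group becomes anilino. Going by the values given here, no measured pair shows what this exchange does here. The expectation rests on the number for compound 1 alone. This exchange is expected to produce a 1.1-fold higher number from compound 1 to compound 3 (0.02 log units; within the scatter), a step within the scatter with no clear direction. Compound 3 is therefore estimated at 12000 nM, within a range from 4000 nM to 36000 nM.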

Compound 3, half-maximal inhibitory concentration: 26200 nM
The estimate for compound 3 lay 2.2-fold (0.34 log units) below the measured number, within the range that was stated.
By their numbers in this assay, from the lowest: compound 2; then compound 1; then compound 3.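

Replacing bromo with hydrogen gives a 2.3-fold higher number from compound 1 to compound 3 (0.36 log units; beyond the scatter) in this assay and turns the (4-bromophenyl)amino group into anilino. Going by these compounds alone, this is the first comparison here that ties a difference to one place in the molecule, and it shows that this position is not indifferent to the exchange: with the shared core left unchanged, the compound with bromo is the stronger inhibitor of the pair, though the step is modest. Nothing available here explains why the number moves with this exchange.

On these data alone, how a chlorine, a methyl group or an amine in place of the bromine would compare remains open. Compound 2 carries a carboxylic acid at this spot but also differs from compound 1 elsewhere, so the effect of the acid alone is unresolved.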